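From acetylmorpholine to methylpyrrolidine on the amide side chain

The source may hold more compounds than are shown below. What is called first, only, known or untested is meant among the compounds shown, and "the series" means these compounds.

Measured so far in a physicochemical assay for solubility, read by spectrophotometry, measured as kinetic solubility, at pH 8, tested at 500 uM (on this read-out lower numbers stand for lower solubility and higher numbers for higher solubility), are three compounds:
compound 1 `CN1CCC(NC(=O)c2ccncc2Nc2cc(-c3ccc4ccn(C)c4c3)c3nccnc3c2)CC1=O` gives 48 ug/mL
compound 2 `CC(=O)N1CCCC(NC(=O)c2ccncc2Nc2cc(-c3ccc4ccn(C)c4c3)c3nccnc3c2)C1` gives 212 ug/mL
compound 3 `CC(=O)N1CCOC(CNC(=O)c2ccncc2Nc2cc(-c3ccc4ccn(C)c4c3)c3nccnc3c2)C1` gives 268 ug/mL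

Compound 3 cannot be told apart from compound 2, and both stand clear of compound 1. The next compound, compound 4 `CN1CCC(CNC(=O)c2ccncc2Nc2cc(-c3ccc4ccn(C)c4c3)c3nccnc3c2)C1`, has not yet been measured. It carries 1-methylpyrrolidin-3-yl in place of 4-acetylmorpholin-2-yl on a saturated chain carbon bound to an amide-type nitrogen, a change that counts out as 1-methylpyrrolidin-3-yl in place of 4-acetylmorpholin-2-yl on a saturated chain carbon bound to an amide-type nitrogen in full.

The three measured compounds differ only in this side group. Exchanges there gave a 4.4-fold higher number from compound 1 to compound 2 (0.65 log units; beyond the scatter) and a 5.6-fold higher number from compound 1 to compound 3 (0.75 log units; beyond the scatter) but also a 1.3-fold higher number from compound 2 to compound 3 (0.10 log units; within the scatter) on the same scale. The group can therefore move the number by a modest amount, or hardly at all. Among the measured compounds shown here, no measured compound carries the 1-methylpyrrolidin-3-yl group, so the direction is poorly supported.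

A slightly lower number is expected, with the estimated change being a 1.6-fold lower number from compound 3 to compound 4 (0.20 log units; within the scatter) in this assay overall. The estimate for compound 4 is 170 ug/mL, with an expected range from 70 ug/mL to 260 ug/mL in this read-out.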

Compound 4, solubility: 246 ug/mL
The estimate for compound 4 lay 1.4-fold (0.16 log units) below the measured number; low and high end bracket the measured number.
By their numbers in this assay, from the lowest: compound 1; then compounds 2, 4 and 3 (each within the scatter of the next).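

In this assay, a five-membered ring with one hetero atom takes the place of a six-membered ring with two, and the acetyl group is gone, yet the number does not shift beyond the scatter (a 1.1-fold lower number from compound 3 to compound 4 (0.04 log units; within the scatter)). So this side group tolerates a large change in ring and substituent without a readable effect, and the same holds against the 1-acetylpiperidin-3-yl side group (a 1.2-fold higher number from compound 2 to compound 4 (0.06 log units; within the scatter)), while the 1-methyl-2-oxopiperidin-4-yl side group remains the only one that stands apart (a 5.1-fold higher number from compound 1 to compound 4 (0.71 log units; beyond the scatter)). No measurement here accounts for why compound 1 differs from the other three.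

As far as these compounds go, whether a carboxylic acid or a primary amine on this side chain, or a longer chain, would move the number beyond the scatter stays open. Also open, from the compounds shown here alone, is whether the ring nitrogen of the 1-methylpyrrolidin-3-yl group matters, which a pyrrolidine without the methyl group or a cyclopentyl ring could test.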